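The compounds below may be only part of what the source reports. "The series", "measured", "known", "first", "only" and "open" are said of these compounds alone.

Measured compounds and their values:

- Compound 1 `CCCOCC(=O)Nc1cc2nc(C3CCCCC3)[nH]c2cc1N(CC)CC` — in an ADME assay on Vero cells (Chlorocebus sabaeus) for cytotoxicity, read by resazurin assay, with a stated time of 3 days (a lower number here means a stronger inhibitor, a higher number a weaker inhibitor), compound 1 gives > 100 ug/mL, which is a limit of the assay and not a number.
- Compound 2 `CCCOCC(=O)Nc1cc2nc(C3CCCCC3)[nH]c2cc1N1CCCC1` — in this assay compound 2 gives > 100 ug/mL, likewise a limit of the assay rather than a number.

Both measured compounds share the same core and differ only in the amine on the aromatic carbon: diethylamino in compound 1, pyrrolidin-1-yl in compound 2. The step between them, a step that the two limits leave unreadable from compound 1 to compound 2, cannot be sized, because of the limit of > 100 ug/mL in this assay, at which 2 of the 2 values shown sit.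

Compound 3 `CCCOCC(=O)Nc1cc2nc(C3CCCCC3)[nH]c2cc1N(C)C` is the next member: dimethylamino in place of pyrrolidin-1-yl on an aromatic carbon. Among the compounds with values here, only one measured step bears on this change, the one from compound 1 to compound 2, and its size is not readable. What the two measured values show is that neither the diethylamino nor the pyrrolidin-1-yl variant reached a measurable level in this assay within the range of the assay. On that basis no step beyond the scatter is expected in this assay from compound 2 to compound 3; the expected step is a step that the limit leaves unreadable from compound 2 to compound 3. Compound 3 is therefore estimated at 150 ug/mL in this assay, with an expected range from 60 ug/mL to 400 ug/mL, and most likely the assay will again report only a limit.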

Compound 3, half-maximal inhibitory concentration: < 50 ug/mL
Compound 3: no number, only a limit (the forecaster's own chance of this, stated with the estimate: 85%); middle value at least 3.0-fold (0.47 log units) from the limit.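

In this assay compound 3 gives < 50 ug/mL, which is a limit of the assay and not a number. Within the data shown here, this is the first sign that the amine on this aromatic carbon, ortho to the ((propoxymethyl)carbonyl)amino group, may make a difference to cytotoxicity on these cells, with an at least 2.0-fold lower number from compound 2 to compound 3 (0.30 log units; that floor lies within the scatter) and an at least 2.0-fold lower number from compound 1 to compound 3 (0.30 log units; that floor lies within the scatter). Compound 1 carries no ring at this place, just as compound 3 does not, so the loss of the ring of pyrrolidin-1-yl cannot by itself be what sets compound 3 apart from both other compounds.

As far as these compounds go, how large the two steps really are stays open, as each is only a floor drawn from limits and none of the three compounds has an actual number in this assay. Also open, from the compounds shown here alone, is where other amines on this carbon would fall, such as a morpholin-4-yl ring, a piperidin-1-yl ring or a methylamino group, and whether a plain amino group would follow dimethylamino or the two larger amines.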